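This account rests on a few compounds, and the source may have more. Where it says the series, first, only, none or still open, it means among the compounds named here.

Compound 2, `CC(C)n1ncc2c(C(=O)Nc3ccccc3F)cc(-c3cccs3)nc21`, stands at the lowest of the two numbers measured in an ADME assay on LLC-MK2 cells (Macaca mulatta) for cytotoxicity, read by spectrophotometry and crystal violet staining, with a stated time of 4 days (a lower number here means that less compound is tolerated, a higher number that more compound is tolerated), giving 50000 nM. Its nearest neighbour is compound 1, `CC(C)n1ncc2c(C(=O)Nc3ncccn3)cc(-c3cccs3)nc21`, which in this assay gives 75000 nM; the step of a 1.5-fold lower number from compound 1 to compound 2 (0.18 log units; within the scatter) lies within the scatter, so the two compounds cannot be ordered on these data. Compound 3, `CC(C)n1ncc2c(C(=O)Nc3ccncn3)cc(-c3cccs3)nc21`, is the next compound to be measured in this assay. It differs from compound 2 in one place: pyrimidin-4-yl in place of 2-fluorophenyl on an amide-type nitrogen. Among the compounds with values here, only one measured step bears on this change, the exchange of pyrimidin-2-yl for 2-fluorophenyl on the same amide-type nitrogen, and that step, a 1.5-fold lower number from compound 1 to compound 2 (0.18 log units; within the scatter), stayed within the scatter. The change now made is of the same kind, run in the opposite direction and with the ring nitrogens placed as in pyrimidin-4-yl. On that single step no movement beyond the scatter is expected from compound 2 to compound 3, and the step of a 1.3-fold higher number from compound 2 to compound 3 (0.11 log units; within the scatter) is therefore estimated to be no larger than the scatter. Compound 3 is accordingly expected to give 65000 nM in this assay, with a range from 30000 nM to 140000 nM.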

Compound 3, half-maximal cytotoxic concentration: 50000 nM
The estimate for compound 3 lay 1.3-fold (0.11 log units) above the measured number; low and high end bracket the measured number.
By their numbers in this assay, from the lowest: compounds 2, 3 and 1 (each within the scatter of the next).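

In this assay, within the data shown here, going from a ring of carbon only bearing fluorine to a six-membered aromatic ring with 2 hetero atoms on the amide-type nitrogen gives no change at the digits printed from compound 2 to compound 3 (within the scatter), so the single exchange seen earlier now has a second example on this position, again without a step beyond the scatter. Among these compounds, the new compound also allows the first comparison of two pyrimidine groups at this place: pyrimidin-4-yl in place of pyrimidin-2-yl gives a 1.5-fold lower number from compound 1 to compound 3 (0.18 log units; within the scatter), so moving the ring nitrogens does not separate these two compounds, and compounds 1, 2 and 3 cannot be ordered on these data. Nothing measured here accounts for this result.

The compounds shown leave open whether a group of another kind on the same amide-type nitrogen, such as a saturated amine like piperidin-4-yl, a longer alkyl chain or a phenyl ring carrying a carboxylic acid, would stay within the scatter of these three in this assay. They also leave open whether these exchanges would read the same way on a core other than the shared core of compound 1.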